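Benzyl group variation toward compound 3

The source may hold more compounds than are shown below. What is called first, only, known or untested is meant among the compounds shown, and "the series" means these compounds.

Measured so far in a functional assay on HT-29 cells (Homo sapiens) for cytotoxicity, read by MTT assay, with a stated time of 48 h; on this read-out lower numbers stand for stronger inhibition and higher numbers for weaker inhibition:
compound 1 `COC(=O)/C=C/c1ccc2c(c1)C(=O)C(=O)N2Cc1cc(C)cc(C)c1` gives 70 nM
compound 2 `CCCCOC(=O)/C=C/c1ccc2c(c1)C(=O)C(=O)N2Cc1ccc(OC)cc1` gives 420 nM

Compound 1 stands at the lowest number of the two. Compound 2 sits at a higher number, and the gap between compound 1 and compound 2 lies beyond the scatter. Compound 2 differs from compound 1 in two places at once, so no single step can be read from that pair; the two values show only that the combination present in compound 2 goes with weaker inhibition in this assay.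

Compound 3 `COC(=O)/C=C/c1ccc2c(c1)C(=O)C(=O)N2Cc1ccc(C#N)cc1` has not yet been measured. Relative to compound 1 the change is 4-cyanophenyl in place of 3,5-dimethylphenyl on a saturated chain carbon bound to an amide-type nitrogen in a ring. Going by the values given here, no measured pair isolates this change, so its size in this assay is open. A modest weakening is expected rather than none, since compound 2 gives 420 nM with a different group at this same place. The expected step of a 2.1-fold higher number from compound 1 to compound 3 (0.33 log units; beyond the scatter) is small, near the edge of the scatter. Compound 3 is estimated at 150 nM, within 50 nM to 450 nM.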

Compound 3, half-maximal inhibitory concentration: 50 nM
Compound 3: the middle estimate sits 3.0-fold (0.48 log units) above what was measured, within the range that was stated.
By their numbers in this assay, from the lowest: compounds 3 and 1 (each within the scatter of the next); then compound 2.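

In this assay, going by these compounds alone, 4-cyanophenyl in place of 3,5-dimethylphenyl on a saturated chain carbon bound to an amide-type nitrogen in a ring gives a 1.4-fold lower number from compound 1 to compound 3 (0.15 log units; within the scatter), the first single-place reading at this position, and it does not tell the two groups apart, although the entering group carries a nitrile that the leaving group lacks. Within the data shown here, compound 2 differs from both compound 1 and compound 3 in two places, the butyl ester and the 4-methoxyphenyl group, so no step involving compound 2 can be read, and its higher number cannot be assigned to the group at this position alone. Nothing in the data at hand speaks to the reason for this result.

From the compounds shown here alone, it remains open whether the butyl ester, the 4-methoxyphenyl group or the two together go with the value of compound 2, and a methyl ester carrying 4-methoxyphenyl would separate them. Also open, going by these compounds, is how this position responds to a group such as an amine on the phenyl ring, and how the series responds to a carboxylic acid in place of the ester.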